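Extending the hydrazone side chain of compound 1

The compounds below may be only part of what the source reports. "The series", "measured", "known", "first", "only" and "open" are said of these compounds alone.

The shared core of the three measured compounds carries a hydrazone side chain; compound 1 `CCC/C(C)=N\Nc1nc(-c2cccc([N+](=O)[O-])c2)cs1`, compound 2 `CCC(CC)=NNc1nc(-c2cccc([N+](=O)[O-])c2)cs1` and compound 3 `CCC/C(CC)=N\Nc1nc(-c2cccc([N+](=O)[O-])c2)cs1` differ only in that chain. In a functional assay, with a stated time of 16 h (on this read-out lower numbers stand for stronger inhibition and higher numbers for weaker inhibition), compound 1 gives 1040000 nM, compound 2 gives 1040000 nM and compound 3 gives 1040000 nM, so compound 1 stands level with both of the others. The three steps among them, no change at the digits printed from compound 1 to compound 2 (within the scatter), no change at the digits printed from compound 1 to compound 3 (within the scatter) and no change at the digits printed from compound 2 to compound 3 (within the scatter), all stay within the scatter.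

Compound 4 `CCCCCC/C(C)=N\Nc1nc(-c2cccc([N+](=O)[O-])c2)cs1` is built from compound 1 by propyl in place of hydrogen on a saturated chain carbon, three bonds along the chain from a carbon with a double bond to nitrogen. This is again a change confined to the chain, and the closest precedents are the steps from compound 1 to compound 3 and from compound 2 to compound 3, which each added a methyl along the same chain without moving the read-out. On that basis no step beyond the scatter is expected in this assay, in either direction, and the estimated step is no change at the digits printed from compound 1 to compound 4 (within the scatter). For compound 4 the expected value is 1040000 nM, within a range of 500000 nM to 2100000 nM.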

Compound 4, half-maximal inhibitory concentration: 1110000 nM
The estimate for compound 4 lay 1.1-fold (0.03 log units) below the measured number; the range from low to high includes it.
By their numbers in this assay, from the lowest: compounds 1, 2, 3 and 4 (each within the scatter of the next).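

Propyl in place of hydrogen on a saturated chain carbon, three bonds along the chain from a carbon with a double bond to nitrogen, gives a 1.1-fold higher number from compound 1 to compound 4 (0.03 log units; within the scatter) in this assay. For the compounds shown here, the earlier steps added only a methyl, so this is the first sign that a larger addition, a propyl, can be made in this chain without a step beyond the scatter. No measurement in hand accounts for this flat read-out.

The compounds shown leave open whether an amine, a carboxylic acid or a chain longer than that of compound 4 in this side chain would move the number beyond the scatter. They also leave open whether any change to the shared core, such as an amine in place of the nitro group, would do so.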